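The compounds below may be only part of what the source reports. "The series", "measured", "known", "first", "only" and "open" are said of these compounds alone.

Three compounds with a shared core were tested in a functional assay for inhibition, using microsomes, tested at 100 ug/mL; a higher number here means a weaker effect of the compound at the concentration tested, a lower number a stronger effect. Compound 1, `COC(=O)C1=C(C)N(c2ccccc2)C=C(C)C1c1ccccc1`, gives -22.7% in this assay. Compound 2, `COC(=O)C1=C(C)N(c2cccc(Cl)c2)C=C(C)C1c1ccccc1`, differs from compound 1 by chloro in place of hydrogen on an aromatic carbon. In this assay compound 2 gives -16.2%; the step of a number 6.5 percentage points higher from compound 1 to compound 2 (within the scatter) is a small one. Compound 3, `CC1=C(C(=O)OC(C)(C)C)C(c2ccccc2)C=CN1c1ccccc1`, gives -35.7%, the lowest of the three numbers; the difference between its core and the core of compound 1 is not broken down here.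

Compound 4, `CC1=C(C(=O)OC(C)(C)C)C(c2ccccc2)C=CN1c1ccc(Cl)cc1`, has not yet been measured. It differs from compound 3 by chloro in place of hydrogen on an aromatic carbon. Among the compounds with values here, this is the same kind of change as the one from compound 1 to compound 2, though not the same: there the chloro sits meta to a large group, here para to a large group. Since the step from compound 1 to compound 2 was a number 6.5 percentage points higher from compound 1 to compound 2 (within the scatter), a change within the scatter, compound 4 is expected to stay near compound 3, with an estimated step of a number 5.7 percentage points higher from compound 3 to compound 4 (within the scatter). Compound 4 is therefore estimated at -30%, likely between -46% and -14%.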

Compound 4, a percentage reported as activity, at one concentration (the size of the read-out at that concentration, not a potency): -18.5%
The estimate for compound 4 lay 11.5 percentage points below the measured number; the measured number falls inside the stated range.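

In this assay, putting chloro in place of hydrogen on compound 3, which turns phenyl into 4-chlorophenyl, gives a number 17.2 percentage points higher from compound 3 to compound 4 (beyond the scatter), so on this core the change weakens the effect at the concentration tested. Set beside the earlier step, this result does not separate the two cores: the same change on two cores in this assay, a number 6.5 percentage points higher (within the scatter) from compound 1 to compound 2 and a number 17.2 percentage points higher (beyond the scatter) from compound 3 to compound 4, 10.7 percentage points apart, within the scatter of two such steps. Within the data shown here, the two steps therefore fit with the change carrying over from one core to the other, but they do not prove that it does: only one of them lies beyond the scatter, there are only two pairs, and the chloro does not sit in the same place in both.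

The compounds shown leave open whether 4-chlorophenyl on the core of compound 1 would give a step like the one seen on the core of compound 3. They also leave open how a different group on that phenyl ring, such as fluoro, an amine or a carboxylic acid, would compare with chloro.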